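The source may report more compounds than this note shows. Statements on the series, on what has been measured and on what is new or still open speak of the compounds shown alone.

Measured in an ADME assay on L6 cells (Rattus norvegicus) for cytotoxicity, read by resazurin assay, with a stated time of 72 h; on this read-out higher numbers stand for weaker inhibition and lower numbers for stronger inhibition:
compound 1 `N=C(N)c1ccc(COc2ccccc2)cc1` gives 167000000 nM
compound 2 `N=C(N)c1ccc(COc2ccc(Cl)cc2)cc1` gives 20700000 nM
compound 3 `N=C(N)c1ccc(COc2ccc(C(=N)N)cc2Cl)cc1` gives 3200000 nM

Compound 4 `N=C(N)c1ccc(COc2c(Cl)cc(C(=N)N)cc2Cl)cc1` is not yet measured. The difference between the core of compound 1 and the core of compound 3 is not broken down here; what the numbers show is that compound 3 gives the lowest number of the three in this assay. The step of an 8.1-fold lower number from compound 1 to compound 2 (0.91 log units; beyond the scatter) came with chloro in place of hydrogen on an aromatic carbon, at a place para to a large group. The change to compound 4 is the same kind of change, (chloro in place of hydrogen on an aromatic carbon), but its place differs: ortho to a large group, meta to a chloro group and meta to a group of 3 heavy atoms. Going by the values given here, only one earlier step of this kind is known, and compound 3 already carries a chloro group, so a smaller step is expected, a 2.9-fold lower number from compound 3 to compound 4 (0.46 log units; beyond the scatter), because compound 3 gives 3200000 nM and the single earlier step was an 8.1-fold lower number from compound 1 to compound 2 (0.91 log units; beyond the scatter). For compound 4 the estimated value in this assay is 1100000 nM, expected between 300000 nM and 3500000 nM.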

Compound 4, half-maximal inhibitory concentration: 28500000 nM
Beside the measured number, compound 4's estimate is 26-fold (1.41 log units) below it, outside the stated range (above it).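

In this assay, chloro in place of hydrogen on an aromatic carbon, ortho to a large group, gives an 8.9-fold higher number from compound 3 to compound 4 (0.95 log units; beyond the scatter). Set beside the earlier step, the same change does not keep its direction from one core to the other: the same change on two cores in this assay, an 8.1-fold lower number (0.91 log units; beyond the scatter) from compound 1 to compound 2 and an 8.9-fold higher number (0.95 log units; beyond the scatter) from compound 3 to compound 4, 72-fold (1.86 log units) apart, beyond the scatter of two such steps

The two steps differ both in core and in the place of the chloro group, so this pair does not show which of the two goes with the reversal, and it gives no rule for other cores in the series. Open, on these data alone, is whether a methyl group, a methoxy group or an amine in place of the added chloro group in compound 4 would move the number the same way. Also open, as far as these compounds go, is how a fluoro or bromo group would behave there.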